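Extending the chain of compound 1 by a further prenyl unit

A few compounds are considered here, and "the series" means these few. Any claim that something is new, unique, unknown or untested is made for them only; others in the source may bear on it.

Compound 1 `CCCCCc1cn(C/C=C(/C)CCC=C(C)C)nn1` stands at the top of the three measured numbers in a physicochemical assay for lipophilicity, measured as octanol-water partition; a higher number here means a more lipophilic compound, a lower number a more polar compound: compound 1 gives 5.45, while compound 3 `CCCCCc1cn(CC=C(C)C)nn1` gives 3.46 and compound 2 `COC(=O)c1cn(C/C=C(/C)CCC=C(C)C)nn1` gives 3.2. The step of a number 1.99 log units lower from compound 1 to compound 3 (beyond the scatter) is a large drop, as is the step of a number 2.25 log units lower from compound 1 to compound 2 (beyond the scatter).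

Compound 4 `CCCCCc1cn(C/C=C(/C)CC/C=C(\C)CCC=C(C)C)nn1` is not yet measured in this assay. It differs from compound 1 by a single change: 3-methylbut-2-en-1-yl in place of hydrogen on a saturated chain carbon bound to a double-bonded chain carbon. The group that enters is the same one that leaves in the step from compound 1 to compound 3, and it enters at the same kind of place, a saturated chain carbon bound to a double-bonded chain carbon. That measured step is therefore the one that bears on this change, and it was large; the step from compound 1 to compound 2 involves an unrelated group on an aromatic carbon and says less here.

Reading the step of a number 1.99 log units lower from compound 1 to compound 3 (beyond the scatter) in reverse, compound 4 is expected to move upward from compound 1 by a number 1.95 log units higher from compound 1 to compound 4 (beyond the scatter). On that basis compound 4 is estimated to give 7.4 in this assay, with a range from 6.6 to 8.2.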

Compound 4, partition coefficient: 7.5
For compound 4 the middle estimate is 0.10 log units below the measured one, and the stated range covers the measured number.
By their numbers in this assay, from the lowest: compounds 2 and 3 (each within the scatter of the next); then compound 1; then compound 4.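

In this assay, within the data shown here, the step of a number 2.05 log units higher from compound 1 to compound 4 (beyond the scatter) shows that this place, a saturated chain carbon bound to a double-bonded chain carbon, also takes the added group with a large rise, whereas the earlier compounds showed only the shortening of the chain of compound 1. Taken with the step of a number 1.99 log units lower from compound 1 to compound 3 (beyond the scatter) in the opposite direction, it places compound 1 between two large steps along this chain, so the number shows no levelling off across the three chain lengths, and none of these compounds goes against that trend. Nothing available explains why the number moves in this way, and no separate measurement bears on the change.

The compounds shown leave open whether a longer chain, with yet another 3-methylbut-2-en-1-yl at the same kind of place, would extend the rise, and whether a hydroxyl group or an amine at that place would reverse it. They also leave open how large the effect of methoxycarbonyl in place of pentyl on an aromatic carbon would be if made on compound 4 rather than on compound 1.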